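Replacing the 3-bromophenyl group of compound 1

The compounds below may be only part of what the source reports. "The series", "measured", "known", "first", "only" and "open" are said of these compounds alone.

Among the compounds with values here, in a functional assay on HT-29 cells (Homo sapiens) for cytotoxicity, read by MTT assay, with a stated time of 72 h (a lower number here means a stronger inhibitor, a higher number a weaker inhibitor), compound 1 `O=C(CN1CCN(c2nnc(Cc3ccncc3)c3ccccc23)CC1)Nc1cccc(Br)c1` gives 1350 nM, the lowest of the three numbers measured so far. Compound 2 `O=C(CN1CCN(c2nnc(Cc3ccccc3)c3ccccc23)CC1)Nc1ccc(F)c(F)c1` gives 9510 nM, and compound 3 `O=C(CN1CCN(c2nnc(Cc3ccccc3)c3ccccc23)CC1)Nc1cccc(F)c1` gives 95000 nM. Compound 4 `O=C(CN1CCN(c2nnc(Cc3ccncc3)c3ccccc23)CC1)Nc1c(F)cccc1F` keeps the core of compound 1 and changes one group: 2,6-difluorophenyl in place of 3-bromophenyl on an amide-type nitrogen. In short, 2,6-difluorophenyl stands in place of 3-bromophenyl on an amide-type nitrogen.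

Within the data shown here, no measured step links compound 1 to any other compound, so the evidence is indirect. Among the measured compounds shown here, the one measured step in this part of the molecule, hydrogen in place of fluoro on an aromatic carbon, is a 10-fold higher number from compound 2 to compound 3 (1.00 log units; beyond the scatter), which lies beyond the scatter. Neither compound in that step carries the 2,6-difluorophenyl group, so it offers only a rough sense of scale. The closest in number to compound 1 is compound 2, which still stands at 9510 nM, so a higher number is expected. The expected change in this assay is a 5.9-fold higher number from compound 1 to compound 4 (0.77 log units; beyond the scatter), towards a weaker inhibitor. For compound 4, the estimated value is 8000 nM, with an expected range of 1500 nM to 50000 nM.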

Compound 4, half-maximal inhibitory concentration: 28700 nM
Estimate against measurement, compound 4: 3.6-fold (0.55 log units) below, and the stated range covers the measured number.
By their numbers in this assay, from the lowest: compound 1; then compound 2; then compound 4; then compound 3.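

Within the data shown here, with the core of compound 1 held fixed, changing only the group on the amide-type nitrogen gives a 21-fold higher number from compound 1 to compound 4 (1.33 log units; beyond the scatter) in this assay as the first direct reading at this position on that core. This shows that the group on this nitrogen can by itself carry a large change in this assay, and that 2,6-difluorophenyl is a much poorer choice here than 3-bromophenyl. No measured property bears on this result, so the step stays an observation without a stated cause.

The swap removes bromine and brings in two fluorines at once, so the compounds shown cannot say how much each contributes. A plain phenyl, 3-chlorophenyl or 3-fluorophenyl group on the same core would help separate these two parts of the change.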